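Removing the Methoxy Group from the Aryl Urea

The source may hold more compounds than are shown below. What is called first, only, known or untested is meant among the compounds shown, and "the series" means these compounds.

Among the compounds with values here, compound 1, `COc1ccc(NC(=O)Nc2nc(Sc3c[nH]c4ccccc34)cc(N3CCCCC3)n2)cc1`, gives 13500 nM in a functional assay on A549 cells (Homo sapiens) for inhibition, with a stated time of 72 h (on this read-out higher numbers stand for weaker inhibition and lower numbers for stronger inhibition), the only number among the three measured compounds. The other two results stand at the limit of > 50000 nM in this assay, at which 2 of the 3 values shown sit. Compound 2, `COc1ccc(NC(=O)Nc2nc(Nc3cc(OC)cc(OC)c3)cc(Sc3c[nH]c4ccccc34)n2)cc1`, is reported in this assay only as a limit, > 50000 nM. Compound 3, `Cc1cc(Cl)ccc1NC(=O)Nc1nc(Sc2c[nH]c3ccccc23)cc(N2CCN(Cc3ccccc3)CC2)n1`, likewise shows in this assay only the limit > 50000 nM. Within the data shown here, the one measured step, an at least 3.7-fold higher number from compound 1 to compound 2 (0.56 log units; beyond the scatter), concerns a different position of the shared core, the amine end rather than the urea. Compound 4, `O=C(Nc1ccccc1)Nc1nc(Sc2c[nH]c3ccccc23)cc(N2CCCCC2)n1`, differs from compound 1 as follows: hydrogen in place of methoxy on an aromatic carbon. Among the measured compounds shown here, no measured step touches the phenyl of the urea, so none bears directly on this change; compound 3 carries a different aryl urea but also a different amine, and its value is a limit only. The analyst therefore expects no movement beyond the scatter, an estimated step of a 1.1-fold higher number from compound 1 to compound 4 (0.05 log units; within the scatter). For compound 4 the estimate in this assay is 15000 nM, with a range from 5000 nM to 45000 nM.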

Compound 4, half-maximal inhibitory concentration: 33100 nM
Estimate against measurement, compound 4: 2.2-fold (0.34 log units) below, and the stated range covers the measured number.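

In this assay, within the data shown here, taking the methoxy group off the urea phenyl gives a 2.5-fold higher number from compound 1 to compound 4 (0.39 log units; beyond the scatter), the first measured step at this end of the molecule. The step is modest but beyond the scatter, so this place, para to a large group, is not indifferent to what it carries: with the piperidin-1-yl group kept, methoxy goes with stronger inhibition than hydrogen. Compound 4 also still gives a number, so the change from 4-methoxyphenyl to phenyl can be read on both sides.

With only methoxy and hydrogen at this place, the compounds leave open how a fluorine, a hydroxyl or an ethoxy group there would read. Whether the step holds with another amine also stays open, since compound 2 and compound 3 each stand only at a limit: the limit of > 50000 nM in this assay, at which 2 of the 4 values shown sit.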